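The compounds below may be only part of what the source reports. "The series", "measured", "known", "first", "only" and "open" are said of these compounds alone.

In a functional assay on DU-145 cells (Homo sapiens) for inhibition, read by trypan blue exclusion, with a stated time of 96 h (a lower number here means a stronger inhibitor of growth, a higher number a weaker inhibitor of growth), compound 1 (`O=C(/C(=C\c1ccc(O)cc1O)Sc1ccc(Br)cc1)c1ccc(Cl)cc1`) gives 50000 nM. Compound 2 (`O=C(/C(=C\c1c(O)cc(O)cc1O)Sc1ccccc1Br)c1ccc(Cl)cc1`) reads > 100000 nM, which is a limit of the assay and not a number. Compound 3 (`O=C(/C(=C\c1ccc(O)cc1O)Sc1ccccc1Br)c1ccc(Cl)cc1`) differs from compound 2 by hydrogen in place of hydroxy on an aromatic carbon, so 2,4,6-trihydroxyphenyl becomes 2,4-dihydroxyphenyl. Among the measured compounds shown here, no measured pair isolates this change. The expected step, an at least 2.0-fold lower number from compound 2 to compound 3 (0.30 log units; that floor lies within the scatter), is a modest gain in growth inhibition. This expectation rests on compound 1, which carries the 2,4-dihydroxyphenyl group and gives 50000 nM. For compound 3 the estimated value is 50000 nM, with an expected range from 20000 nM to 100000 nM.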

Compound 3, concentration for 50% growth inhibition: 50000 nM
The estimate for compound 3 equals the measured number at the digits printed; the range from low to high includes it.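

With hydrogen in place of hydroxy on this aromatic carbon, this assay shows an at least 2.0-fold lower number from compound 2 to compound 3 (0.30 log units; that floor lies within the scatter). That step has a floor but no measured size, since compound 2 stands at a limit of the assay: the limit of > 100000 nM in this assay, at which 1 of the 3 values shown sits. With 2-bromophenyl in place of 4-bromophenyl on the sulfur, the same assay, this assay, shows no change at the digits printed from compound 1 to compound 3 (within the scatter), so these two bromine placements cannot be told apart here.

As far as these compounds go, it remains open whether an amine or a methoxy group at this aromatic carbon would read differently from hydrogen. Also open, from the compounds shown here alone, is how a 3-bromophenyl group on the sulfur would read.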